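This account rests on a few compounds, and the source may have more. Where it says the series, first, only, none or still open, it means among the compounds named here.

Measured in a functional assay on HeLa cells (Homo sapiens) for inhibition; a higher number here means a weaker inhibitor, a lower number a stronger inhibitor:
compound 1 `Oc1cccc(-c2cc(-c3ccccc3F)cc(-c3cccc(O)c3)n2)c1` — 16000 nM
compound 2 `Oc1cccc(-c2cc(-c3ccccc3C(F)(F)F)cc(-c3cccc(O)c3)n2)c1` — 15200 nM
compound 3 `Oc1ccc(-c2cc(-c3ccccc3C(F)(F)F)cc(-c3cccc(O)c3)n2)cc1` — 17400 nM

Compound 2 carries the lowest number of the three, but the margins are narrow: a 1.1-fold lower number from compound 1 to compound 2 (0.02 log units; within the scatter) and a 1.1-fold higher number from compound 2 to compound 3 (0.06 log units; within the scatter) both fall within the scatter, so nothing separates the three compounds in this assay. The step now under consideration leads from compound 2 to compound 4 `Oc1cccc(-c2cc(-c3ccccc3OC(F)(F)F)cc(-c3cccc(O)c3)n2)c1`: trifluoromethoxy in place of trifluoromethyl on an aromatic carbon. Going by the values given here, of the measured steps, only the one that alters the same group bears directly on it: the change from fluoro to trifluoromethyl at that place, a 1.1-fold lower number from compound 1 to compound 2 (0.02 log units; within the scatter), left the number essentially where it was. The exchange of 3-hydroxyphenyl for 4-hydroxyphenyl, a 1.1-fold higher number from compound 2 to compound 3 (0.06 log units; within the scatter), concerns another part of the molecule and likewise moved nothing. Against this flat background, and with no measured step that exceeds the scatter, a further exchange at the same aromatic carbon is expected to give no step beyond the scatter in this assay, in either direction. The expected step is a 1.0-fold lower number from compound 2 to compound 4 (0.01 log units; within the scatter). Compound 4 is accordingly estimated at about 15000 nM, with a range from 7000 nM to 32000 nM.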

Compound 4, half-maximal inhibitory concentration: 16700 nM
Compound 4: middle estimate off by 1.1-fold (0.05 log units), on the low side; low and high end bracket the measured number.
By their numbers in this assay, from the lowest: compounds 2, 1, 4 and 3 (each within the scatter of the next).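

In this assay, going by these compounds alone, the first oxygen-bearing group at this aromatic carbon, ortho to a large group, gives a 1.1-fold higher number from compound 2 to compound 4 (0.04 log units; within the scatter), so the extra oxygen of trifluoromethoxy and its one more heavy atom than trifluoromethyl leave no readable mark on the number. The comparison with the smallest group shown at this place gives a 1.0-fold higher number from compound 1 to compound 4 (0.02 log units; within the scatter), so fluoro, trifluoromethyl and trifluoromethoxy now form a set of three exchanges at one carbon, none separable from the others in this assay, and no compound among the three goes against this flatness. No measurement is available that would account for this insensitivity.

Every group shown at this carbon carries fluorine, so it remains open whether an amine, a carboxylic acid or a longer alkyl chain there would give a step beyond the scatter in this assay. The compounds shown also leave open how far the number depends on the two hydroxyl groups, since only one shift of a hydroxyl is shown and replacement by a methoxy or an amine does not appear among them.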